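Replacing the bromobenzyl group of compound 2 with a piperidinylethyl chain

The source may report more compounds than this note shows. Statements on the series, on what has been measured and on what is new or still open speak of the compounds shown alone.

Compound 1 `CN(C)CCCN(Cc1ccccc1)c1cccc(C(=O)N2CCc3ccc(OS(N)(=O)=O)cc3C2)c1` gives 23.8% in an assay on HEK293 cells for inhibition of Steryl-sulfatase (Homo sapiens), tested at 0.1 uM; a lower number here means a weaker effect, a higher number a stronger effect of the compound at the concentration tested.
Compound 2 `CCN(Cc1ccc(Br)cc1)c1ccc(C(=O)N2CCc3ccc(OS(N)(=O)=O)cc3C2)cc1` gives 78.2% in this assay.
Compound 3 `CN(C)CCN(Cc1ccccc1)c1cccc(C(=O)N2CCc3ccc(OS(N)(=O)=O)cc3C2)c1` gives 0% in this assay.

Compound 2 stands highest of the three numbers; compound 1 is nearest to it and compound 3 furthest, and both gaps lie beyond the scatter. Compound 4 `CN(CCN1CCCCC1)c1ccc(C(=O)N2CCc3ccc(OS(N)(=O)=O)cc3C2)cc1` has not yet been measured. methyl(2-(piperidin-1-yl)ethyl)amino in place of (4-bromobenzyl)(ethyl)amino on an aromatic carbon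

Going by the values given here, only one measured step is available, a number 23.8 percentage points lower from compound 1 to compound 3 (beyond the scatter), and it bears on compound 4 only at a distance: it compares two compounds that both carry a basic amine on a saturated chain, and shortening that chain produced a modest drop. Compound 4 also carries a basic amine on a saturated chain, while it gives up the aromatic ring of the leaving group that compound 2 has. Among the measured compounds, those with such chains sit low: compound 1 gives 23.8% and compound 3 gives 0%, whereas compound 2 gives 78.2%. On this basis a large fall is expected, a number 58.2 percentage points lower from compound 2 to compound 4 (beyond the scatter). Compound 4 is therefore estimated at 20%, with a range from 0% to 50%.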

Compound 4, a percentage reported as inhibition, at one concentration (the size of the read-out at that concentration, not a potency): 0.3%
For compound 4 the middle estimate is 19.7 percentage points above the measured one, within the range that was stated.
By their numbers in this assay, from the lowest: compounds 3 and 4 (each within the scatter of the next); then compound 1; then compound 2.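

In this assay, the substituent on the aromatic carbon para to a large group proves decisive for the read-out: exchanging (4-bromobenzyl)(ethyl)amino for methyl(2-(piperidin-1-yl)ethyl)amino gives a number 77.9 percentage points lower from compound 2 to compound 4 (beyond the scatter) and leaves compound 4 at 0.3% at the concentration tested. The earlier step showed only what shortening a chain does while the benzyl group stays in place, whereas this change removes the six-membered aromatic ring of carbon only and the bromine and brings in a six-membered non-aromatic ring with one hetero atom. Nothing available explains the size of this loss.

Both groups on the nitrogen differ from compound 2 to compound 4, so the compounds shown do not separate the loss of the 4-bromobenzyl group from the gain of the piperidinylethyl chain, or the ethyl group from the methyl group. From the compounds shown here alone, it remains open whether a benzyl group without the bromine would hold the read-out at this position, and whether a morpholine ring or a longer chain in place of the piperidine would restore any of it.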